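A few compounds are considered here, and "the series" means these few. Any claim that something is new, unique, unknown or untested is made for them only; others in the source may bear on it.

Measured so far:
compound 1 `COc1cc(-c2cc(/C=C/C(=O)c3ccc(N)cc3)[nH]n2)cc(OC)c1OC`: -58%
compound 2 `COc1cc(-c2cc(/C=C/C(=O)c3ccc(Cl)c(Cl)c3)[nH]n2)cc(OC)c1OC`: -13%

In a functional assay on MDA-MB-468 cells (Homo sapiens) for cytotoxicity, read by sulforhodamine B assay, with a stated time of 48 h, tested at 10 uM (on this read-out higher numbers stand for a weaker effect at the one concentration tested and lower numbers for a stronger effect), compound 1 gives -58% and compound 2 gives -13%. Among the compounds with values here, compound 2 thus stands highest of the two numbers, and the one measured step, a number 45 percentage points higher from compound 1 to compound 2 (beyond the scatter), is large and beyond the scatter. The next compound is compound 3 `COc1ccc(C(=O)/C=C/c2cc(-c3cc(OC)c(OC)c(OC)c3)n[nH]2)cc1OC`, not yet measured. Against compound 2 the change is 3,4-dimethoxyphenyl in place of 3,4-dichlorophenyl on a carbonyl carbon. Within the data shown here, the only measured step that concerns the same carbonyl carbon started from a different group, so it shows that this position moves the read-out strongly but gives no direct measure of 3,4-dimethoxyphenyl against 3,4-dichlorophenyl. With nothing closer to lean on, a moderate step back toward the number of compound 1 is expected, estimated as a number 17 percentage points lower from compound 2 to compound 3 (beyond the scatter), with wide uncertainty. For compound 3 the expected value in this assay is -30%, with a range of -60% to 0%.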

Compound 3, a percentage reported as activity, at one concentration (the size of the read-out at that concentration, not a potency): -87%
Estimate against measurement, compound 3: 57 percentage points above; measured number below the stated range.
By their numbers in this assay, from the lowest: compound 3; then compound 1; then compound 2.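

In this assay, the carbonyl carbon position proves able to move the read-out in both directions: (a number 74 percentage points lower from compound 2 to compound 3 (beyond the scatter)) with 3,4-dimethoxyphenyl in place of 3,4-dichlorophenyl, so the two disubstituted phenyl groups are far from interchangeable. The further step (a number 29 percentage points lower from compound 1 to compound 3 (beyond the scatter)) shows that 3,4-dimethoxyphenyl also goes beyond 4-aminophenyl, which makes compound 3 the strongest of the three at the one concentration tested. Nothing available accounts for these differences.

The compounds shown leave open whether both methoxy groups are needed, which a 4-methoxyphenyl or 3-methoxyphenyl group on the same carbonyl carbon would address. Also open, from the compounds shown here alone, is whether the order of these three groups holds when the shared core carries a change elsewhere.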